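A few compounds are considered here, and "the series" means these few. Any claim that something is new, unique, unknown or untested is made for them only; others in the source may bear on it.

The study concerns a shared core, seen in compound 1 `Cc1nc(N(C)c2ccc([Se]C#N)c(Cl)c2)c2ccccc2n1`, compound 2 `COc1ccc(N(C)c2nc(C)nc3ccccc23)cc1OCCN` and compound 3 `C[Se]c1ccc(N(C)c2nc(C)nc3ccccc23)cc1C`, tested in a functional assay on HepG2 cells (Homo sapiens) for inhibition, read by MTT assay, with a stated time of 48 h; a lower number here means a stronger inhibitor, a higher number a weaker inhibitor. In this assay compound 1 gives 12 nM, compound 3 gives 6 nM, and compound 2 gives 343 nM. Compound 2 thus stands highest of the three numbers: its nearest neighbour is compound 1, a gap beyond the scatter, and the furthest is compound 3, a still wider gap, also beyond the scatter. Within the data shown here, no single-change step between the measured compounds is available, so the account rests on the values themselves.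

Compound 4 `COc1ccc(N(C)c2nc(C)nc3ccccc23)cc1[Se]C#N` has not yet been measured in this assay. Compared with compound 2 it differs in one place: a group of 3 heavy atoms (1 carbon, 1 nitrogen, 1 selenium; no ring) in place of a group of 4 heavy atoms (2 carbon, 1 nitrogen, 1 oxygen; no ring), on an aromatic carbon. The entering group carries selenium, as do the groups found in compound 1 and compound 3, whose numbers sit far below that of compound 2.

On that basis compound 4 is expected to fall well below compound 2, a step of a 23-fold lower number from compound 2 to compound 4 (1.36 log units; beyond the scatter) that is expected to lie beyond the scatter. The estimate for compound 4 in this assay is 15 nM, with a range from 4 nM to 60 nM.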

Compound 4, half-maximal inhibitory concentration: 59 nM
Compound 4: middle estimate off by 3.9-fold (0.59 log units), on the low side; the measured number falls inside the stated range.
By their numbers in this assay, from the lowest: compounds 3 and 1 (each within the scatter of the next); then compound 4; then compound 2.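

In this assay, among these compounds, the aromatic carbon ortho to a methoxy group proves sensitive to what it carries: replacing the 2-aminoethoxy group with the selenium-bearing group gives a 5.8-fold lower number from compound 2 to compound 4 (0.76 log units; beyond the scatter), a step beyond the scatter and the first single-change comparison. The change swaps a group with a hydrogen-bond donor for one with none and a triple bond outside aromatic rings, while the rest of the molecule stays the same, so the difference in the numbers belongs to this one exchange. Nothing measured in the material shown accounts for the size of this step.

From the compounds shown here alone, what remains open is which part of the exchange matters, the presence of selenium, the triple bond or the loss of the 2-aminoethoxy group, since all three change together in this single step. A plain nitrile or a bromine atom on the same aromatic carbon, or a longer aminoalkoxy chain in place of the 2-aminoethoxy group, would be needed to separate these parts, and the compounds shown include none of these.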